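A Phenylpiperidine Tail in Place of Dimethylamino on Compound 1

A few compounds are considered here, and "the series" means these few. Any claim that something is new, unique, unknown or untested is made for them only; others in the source may bear on it.

Compound 1 `COc1cc2c(Nc3ccc(C#N)cc3)ncnc2cc1OCCCN(C)C` shows only a limit in a functional assay on HepG2 cells (Homo sapiens) for antiproliferative activity, read by MTT assay, with a stated time of 72 h (a higher number here means a weaker inhibitor, a lower number a stronger inhibitor), where compound 1 gives > 100000 nM. Compound 2 `CCN(CC)CCCOc1cc2ncnc(Nc3ccc(C#N)cc3)c2cc1OC` gives 59400 nM in this assay. Compound 3 `CCOC(=O)C1CCN(CCCOc2cc3ncnc(Nc4ccc(C#N)cc4)c3cc2OC)CC1` gives 57700 nM in this assay. The steps among these three are small: an at least 1.6-fold lower number from compound 1 to compound 2 (0.22 log units; that floor lies within the scatter), an at least 1.7-fold lower number from compound 1 to compound 3 (0.23 log units; that floor lies within the scatter) and a 1.0-fold lower number from compound 2 to compound 3 (0.01 log units; within the scatter). Compound 4 `COc1cc2c(Nc3ccc(C#N)cc3)ncnc2cc1OCCCN1CCC(c2ccccc2)CC1` differs from compound 1 by 4-phenylpiperidin-1-yl in place of dimethylamino on a saturated chain carbon, three bonds along the chain from an oxygen on an aromatic ring. Because an at least 1.6-fold lower number from compound 1 to compound 2 (0.22 log units; that floor lies within the scatter) and an at least 1.7-fold lower number from compound 1 to compound 3 (0.23 log units; that floor lies within the scatter) both sit at floors within the scatter, only a modest lowering is expected from this larger tail. Compound 4 is therefore expected to show an at least 2.5-fold lower number from compound 1 to compound 4 (0.39 log units; beyond the scatter). The estimate for compound 4 in this assay is 40000 nM, with a range from 15000 nM to 100000 nM.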

Compound 4, half-maximal inhibitory concentration: 4610 nM
For compound 4 the middle estimate is 8.7-fold (0.94 log units) above the measured one; the measured number lies below the stated range.
By their numbers in this assay, from the lowest: compound 4; then compounds 3 and 2 (each within the scatter of the next). At a limit, above all of these: compound 1.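

The earlier tails on this saturated chain carbon left the number within the scatter of one another, but a tail carrying a phenyl ring moves it well beyond the scatter. Phenyl in place of ethoxycarbonyl on a saturated ring carbon gives a 13-fold lower number from compound 3 to compound 4 (1.10 log units; beyond the scatter), and 4-phenylpiperidin-1-yl in place of diethylamino gives a 13-fold lower number from compound 2 to compound 4 (1.11 log units; beyond the scatter). Against the dimethylamino tail the change gives an at least 21-fold lower number from compound 1 to compound 4 (1.33 log units; beyond the scatter), a step that is only a floor, resting on a limit of the assay: the limit of > 100000 nM in this assay, at which 1 of the 4 values shown sits.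

The compounds shown leave open whether a cyclohexyl group in place of the phenyl, or a longer chain leading to the piperidine, would keep this lower number.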